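A few compounds are considered here, and "the series" means these few. Any claim that something is new, unique, unknown or untested is made for them only; others in the source may bear on it.

Measured so far:
compound 1 `CCSS/C(CCOC(=O)[C@@H](C)c1ccc2cc(OC)ccc2c1)=C(/C)N(C=O)CC(=O)OC[C@H]1O[C@H](O)[C@H](O)[C@@H](O)[C@@H]1O` — 27.2 h
compound 2 `COc1ccc2cc([C@H](C)C(=O)OCC/C(SSC(C)C)=C(\C)N(C=O)CC(=O)OC[C@H]3O[C@H](O)[C@H](O)[C@@H](O)[C@@H]3O)ccc2c1` — 51 h

In a physicochemical assay for pharmacokinetics, read by HPLC, in phosphate buffer, at pH 7.4 (a higher number here means that the compound lasts longer, a lower number that the compound disappears faster), compound 1 gives 27.2 h, and compound 2 gives 51 h. For the measured compounds named here, compound 2 stands highest of the two numbers, but its nearest neighbour is compound 1, and the single measured step, a 1.9-fold higher number from compound 1 to compound 2 (0.27 log units; within the scatter), lies within the scatter, so the two values cannot be ordered with confidence.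

Compound 3 `COc1ccc2cc([C@H](C)C(=O)OCC/C(SSCc3ccccc3)=C(\C)N(C=O)CC(=O)OC[C@H]3O[C@H](O)[C@H](O)[C@@H](O)[C@@H]3O)ccc2c1` is the next member of the series. It differs from compound 2 in one place: benzyl in place of isopropyl on a sulfur. Going by the values given here, no measured step touches that position. Among the compounds with values here, the only step available, from compound 1 to compound 2, concerns a methyl on a saturated chain carbon and has nothing to say about a benzyl in place of an isopropyl on the disulfide sulfur. There is therefore no basis for expecting a change beyond the scatter, and the value of compound 2 is the natural anchor.

Compound 3 is accordingly expected to give about 45 h in this assay, with a range of 18 h to 110 h. The step that this estimate implies, a 1.1-fold lower number from compound 2 to compound 3 (0.05 log units; within the scatter), is expected to stay within the scatter.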

Compound 3, half-life: 30.1 h
Compound 3: the middle estimate sits 1.5-fold (0.17 log units) above what was measured; measured number inside the range.
By their numbers in this assay, from the lowest: compounds 1, 3 and 2 (each within the scatter of the next).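

In this assay, for the compounds shown here, benzyl in place of isopropyl on a sulfur gives a 1.7-fold lower number from compound 2 to compound 3 (0.23 log units; within the scatter), the first reading at this position, and the entering six-membered aromatic ring of carbon only does not move the number beyond the scatter. The comparison with compound 1 points the same way: phenyl in place of methyl on a saturated chain carbon bound to a sulfur gives a 1.1-fold higher number from compound 1 to compound 3 (0.04 log units; within the scatter), so compound 1, compound 2 and compound 3 cannot be told apart in this assay, and these three groups on the sulfur give no order. Nothing measured here accounts for this outcome or for the small differences among the three numbers.

All the groups shown on this sulfur are made of carbon only, so it stays open whether an amine, a carboxylic acid or a longer chain at the same place would give a step beyond the scatter. The half-lives also leave open which part of these molecules gives way in the buffer, and whether the same closeness would hold in any setting other than this assay.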